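Chloropyridine amide joins benzothiazole series at the assay limit

The compounds below may be only part of what the source reports. "The series", "measured", "known", "first", "only" and "open" are said of these compounds alone.

Compound 1 `O=C(Nc1ccc(Cl)cc1)c1cc([N+](=O)[O-])ccc1Cl`: in an ADME assay on BJ cells (Homo sapiens) for inhibition, with a stated time of 72 h (on this read-out higher numbers stand for an effect only at larger amounts of compound and lower numbers for an effect already at smaller amounts), compound 1 gives > 25000 nM, a limit of the assay and not a number.
Compound 2 `O=C(O)/C=C/C(=O)Nc1cccc(-c2nc3ccccc3s2)c1`: in this assay compound 2 gives > 25000 nM, again a limit.
Compound 3 `CC(C)(CCl)C(=O)Nc1cccc(-c2nc3ccccc3s2)c1`: in this assay compound 3 gives > 25000 nM, also a limit.

Compound 3 therefore stands nowhere within the measurable numbers; its value is a limit, and the two other values shown are limits as well, as summed up by the limit of > 25000 nM in this assay, at which 3 of the 3 values shown sit. Among the compounds with values here, the one step between measured compounds that differ in a single place, a step that the two limits leave unreadable from compound 2 to compound 3, is unreadable because both ends are limits.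

Compound 4 `O=C(Nc1cccc(-c2nc3ccccc3s2)c1)c1ccncc1Cl` differs from compound 3 by 3-chloropyridin-4-yl in place of 1-(chloromethyl)-1-methylethyl on a carbonyl carbon. Within the data shown here, no measured step bears on this change in a readable way, since the only step available, from compound 2 to compound 3, sits between two limits. Given that compound 3 and every other measured compound sit at the limit, compound 4 is expected to stay there too, with a step that the limit leaves unreadable from compound 3 to compound 4 that is not expected to exceed the scatter. The estimate for compound 4 in this assay is 30000 nM, within a range from 10000 nM to 100000 nM, most probably reported only as a limit.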

Compound 4, half-maximal effective concentration: > 25000 nM
Compound 4: no number, only a limit; the forecaster's own chance of this, stated with the estimate: 80%; the middle value does not contradict the limit.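

The result for compound 4 is again a limit, so the steps linking it to compound 2 and compound 3 cannot be read in this assay: the limit of > 25000 nM in this assay, at which 4 of the 4 values shown sit.

The compounds shown leave open whether any group on the carbonyl carbon of the shared core brings the half-maximal effective concentration to a readable number.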